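One Amide Change, Measured Once, Expected Again

A few compounds are considered here, and "the series" means these few. Any claim that something is new, unique, unknown or untested is made for them only; others in the source may bear on it.

Of the compounds shown here, three of this set have been measured in a physicochemical assay for lipophilicity, read by HPLC, measured as chromatographic lipophilicity, at pH 7.4; a higher number here means a more lipophilic compound, a lower number a more polar compound. Compound 1 `CC[C@H]1OC(=O)[C@H](C)[C@@H](O[C@H]2C[C@@](C)(OC)[C@@H](O)[C@H](C)O2)[C@H](C)[C@@H](O[C@@H]2O[C@H](C)C[C@H](N(C)C)[C@H]2O)[C@](C)(O)C[C@@H](C)CN(C)[C@H](C)[C@@H](OCCCNC(=O)COC)[C@]1(C)O` gives 2.58 in this assay. Compound 2 `CC[C@H]1OC(=O)[C@H](C)[C@@H](O[C@H]2C[C@@](C)(OC)[C@@H](O)[C@H](C)O2)[C@H](C)[C@@H](O[C@@H]2O[C@H](C)C[C@H](N(C)C)[C@H]2O)[C@](C)(O)C[C@@H](C)CN(C)[C@H](C)[C@@H](OCCCNC(=O)c2c(C)nn(C)c2Cl)[C@]1(C)O` differs from compound 1 at a single place, a carbonyl carbon whose other neighbour is an amide-type nitrogen, where the methoxymethyl is replaced by a 5-chloro-1,3-dimethyl-1H-pyrazol-4-yl; the counted difference is 5-chloro-1,3-dimethyl-1H-pyrazol-4-yl in place of methoxymethyl on a carbonyl carbon. In this assay compound 2 gives 3.01, and the step of a number 0.43 log units higher from compound 1 to compound 2 (beyond the scatter) lies beyond the scatter of the method.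

Compound 3 `CC[C@H]1OC(=O)[C@H](C)[C@@H](O[C@H]2C[C@@](C)(OC)[C@@H](OCCCNC(=O)COC)[C@H](C)O2)[C@H](C)[C@@H](O[C@@H]2O[C@H](C)C[C@H](N(C)C)[C@H]2O)[C@](C)(O)C[C@@H](C)CN(C)[C@H](C)[C@@H](O)[C@]1(C)O` is built from the same atoms as compound 1, joined differently; the difference between the two cores is not broken down here. In this assay compound 3 gives 2.16, the lowest of the three numbers, with both other compounds standing beyond the scatter above it.

Compound 4 `CC[C@H]1OC(=O)[C@H](C)[C@@H](O[C@H]2C[C@@](C)(OC)[C@@H](OCCCNC(=O)c3c(C)nn(C)c3Cl)[C@H](C)O2)[C@H](C)[C@@H](O[C@@H]2O[C@H](C)C[C@H](N(C)C)[C@H]2O)[C@](C)(O)C[C@@H](C)CN(C)[C@H](C)[C@@H](O)[C@]1(C)O` has not yet been measured in this assay. It differs from compound 3 by 5-chloro-1,3-dimethyl-1H-pyrazol-4-yl in place of methoxymethyl on a carbonyl carbon. The place is described in the same words for both pairs, so this is the same change that was made from compound 1 to compound 2, now made on the core of compound 3.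

For the measured compounds named here, the size of the step from compound 3 to compound 4 is expected to be about a number 0.43 log units higher from compound 3 to compound 4 (beyond the scatter), because the only measured instance of this change, a number 0.43 log units higher from compound 1 to compound 2 (beyond the scatter), gave a step of that size. On this basis compound 4 is expected to give about 2.59 in this assay. The estimate for compound 4 is expected to fall between 2.3 and 2.9, allowing for the usual scatter and for the change being carried onto a differently joined core.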

Compound 4, distribution coefficient: 2.52
Beside the measured number, compound 4's estimate is 0.07 log units above it, and the stated range covers the measured number.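

In this assay, putting 5-chloro-1,3-dimethyl-1H-pyrazol-4-yl in place of methoxymethyl on a carbonyl carbon gives a number 0.36 log units higher from compound 3 to compound 4 (beyond the scatter) on the core of compound 3, and the same change gave a number 0.43 log units higher from compound 1 to compound 2 (beyond the scatter) on the core of compound 1; on both cores the step therefore runs in the same direction, is modest, and lies beyond the scatter. For the compounds shown here, this shows that the change carried from one of these two differently joined cores to the other, but it rests on only two pairs, so it does not show that the step would hold on any further core or that the two steps are identical in size. Nothing shown here offers an explanation for the direction or the size of the step on either core.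

The compounds shown leave open whether a different group on the same carbonyl carbon, such as a phenyl ring or a carbon chain longer than methoxymethyl, would also give matching steps on the two cores. They also leave open how an amine or a carboxylic acid at that place would behave, since each such group would need its own pair on each core.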